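Cyclobutylsulfonyl to tert-butylsulfamoyl on the aryl sulfone

The source may report more compounds than this note shows. Statements on the series, on what has been measured and on what is new or still open speak of the compounds shown alone.

Measured compounds:
- compound 1 `CCN(CC)S(=O)(=O)c1ccc(S(=O)(=O)N2CCC[C@@H](C(=O)NC3CN(C(=O)OC(C)(C)C)C3)C2)cc1`: 100 nM
- compound 2 `CCOC(=O)[C@@H]1CCCN(S(=O)(=O)c2ccc(S(=O)(=O)N(CC)C(C)C)cc2)C1`: 1200 nM
- compound 3 `CC(C)c1noc(N2CCN(C(=O)[C@@H]3CCCN(S(=O)(=O)c4ccc(S(=O)(=O)C5CCC5)cc4)C3)CC2)n1`: 20 nM

In a functional assay on MIA PaCa-2 cells (Homo sapiens) for inhibition, read by MTT assay, with a stated time of 3 days (on this read-out lower numbers stand for stronger inhibition and higher numbers for weaker inhibition), compound 3 gives 20 nM, the lowest number of the three. Compound 1 gives 100 nM and compound 2 gives 1200 nM; both steps from compound 3 lie beyond the scatter, so compound 3 stands as the strongest inhibitor of the set. Compound 1 and compound 2 differ from compound 3 in more than one place, so no single change among the measured compounds can be read off.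

Compound 4 `CC(C)c1noc(N2CCN(C(=O)[C@@H]3CCCN(S(=O)(=O)c4ccc(S(=O)(=O)NC(C)(C)C)cc4)C3)CC2)n1` keeps the shared core of compound 3 and differs only at the sulfonyl sulfur on the aromatic ring: (tert-butyl)amino in place of cyclobutyl on a sulfonyl sulfur. Cut one bond further out this reads cyclobutylsulfonyl to (tert-butyl)sulfamoyl. Among the compounds with values here, no measured pair shows this change, so the size of the step is uncertain; a small step, most likely within the scatter or slightly toward a higher number, is expected. Compound 4 is estimated at 35 nM, range 10 nM to 120 nM, which means an expected step of a 1.8-fold higher number from compound 3 to compound 4 (0.24 log units; within the scatter).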

Compound 4, half-maximal inhibitory concentration: 100 nM
For compound 4 the middle estimate is 2.9-fold (0.46 log units) below the measured one; the measured number falls inside the stated range.
By their numbers in this assay, from the lowest: compound 3; then compounds 1 and 4 (each within the scatter of the next); then compound 2.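

In this assay, the sulfonyl sulfur on the aromatic ring proves sensitive to its substituent: (tert-butyl)amino in place of cyclobutyl gives a 5.0-fold higher number from compound 3 to compound 4 (0.70 log units; beyond the scatter). Within the data shown here, this is the first comparison that differs in one place, but that one change both removes the four-membered ring and adds a hydrogen-bond donor, and this pair cannot separate the two. No supporting evidence bears on the origin of the step.

Which part of the change accounts for the step remains open: a cyclobutylamino group on the same sulfur would keep the ring and the donor, while a tert-butyl group directly on it would keep the branched shape without the donor. Whether the step carries over to other amides on the shared core is also unresolved.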